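Fluorophenyl in Place of Thiophene on a Shared Core

The source may report more compounds than this note shows. Statements on the series, on what has been measured and on what is new or still open speak of the compounds shown alone.

Compound 1 `CN(C)CCCCCCCOc1ccc2oc(-c3ccccc3)cc(=O)c2c1`: 165 nM
Compound 2 `O=c1cc(-c2cccs2)oc2ccc(OCCCCCCN3CCC(O)CC3)cc12`: 119 nM

Both numbers come from an assay on isolated protein (Cavia porcellus) with Sigma non-opioid intracellular receptor 1 (Homo sapiens) as the target, read by radioligand binding; on this read-out lower numbers stand for stronger inhibition and higher numbers for weaker inhibition. For the measured compounds named here, compound 2 and compound 1 lie within the scatter of each other, so the two measurements cannot be told apart, and no step between them is recorded. Compound 3 `O=c1cc(-c2ccc(F)cc2)oc2ccc(OCCCCCCN3CCC(O)CC3)cc12` has not yet been measured. It differs from compound 2 in one place: 4-fluorophenyl in place of thiophen-2-yl on an aromatic carbon. Going by the values given here, since the two measured compounds agree within the scatter and differ from compound 3 in more than this one place, the account offers no direct step for this change; compound 2 with a thiophen-2-yl group and compound 1 with a phenyl group on a different chain both sit in a similar range. Compound 3 is therefore expected to stay near compound 2, with no step beyond the scatter, giving an estimated 120 nM (range 50 nM to 300 nM). This corresponds to an expected step of a 1.0-fold higher number from compound 2 to compound 3 (0.00 log units; within the scatter).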

Compound 3, half-maximal inhibitory concentration: 95 nM
Compound 3: middle estimate off by 1.3-fold (0.10 log units), on the high side; the range from low to high includes it.
By their numbers in this assay, from the lowest: compounds 3, 2 and 1 (each within the scatter of the next).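

In this assay, for the compounds shown here, 4-fluorophenyl in place of thiophen-2-yl on the aromatic carbon next to the ring oxygen gives a 1.3-fold lower number from compound 2 to compound 3 (0.10 log units; within the scatter), the first one-place comparison at this position. The shared core thus carries either a five-membered aromatic ring with sulfur or a six-membered aromatic ring of carbon only bearing fluorine, and this read-out cannot tell the two compounds apart. Nothing available explains the result, and no separate measurement bears on it.

The compounds shown leave open whether the fluorine matters at all, since no pair isolates it on this chain. They also leave open whether a methoxy group, an amine or a carboxylic acid on the phenyl ring would move the number beyond the scatter.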